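A few compounds are considered here, and "the series" means these few. Any claim that something is new, unique, unknown or untested is made for them only; others in the source may bear on it.

Measured in a functional assay on A549 cells (Homo sapiens) for inhibition, read by MTT assay, with a stated time of 48 h (a higher number here means a weaker inhibitor, a lower number a stronger inhibitor), so far:
- Compound 1 (`COc1ccc(CNC(=O)/C=C/c2coc3cc(O)ccc3c2=O)cc1`) gives > 100000 nM as a limit
- Compound 2 (`COc1ccc2c(=O)c(/C=C/C(=O)NCc3ccc(C)cc3)coc2c1`) gives > 100000 nM as a limit

Compound 2 has only a limit and no number: it stands at the limit of > 100000 nM in this assay, at which 2 of the 2 values shown sit, and nothing finer can be read from it.

Compound 3 (`Cc1ccc(CNC(=O)/C=C/c2coc3cc(O)ccc3c2=O)cc1`) is not yet measured. It differs from compound 2 by hydrogen in place of methyl on an oxygen on an aromatic ring (hydrogen in place of methyl on an oxygen on an aromatic ring, that is, methoxy to hydroxy).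

Among the compounds with values here, no measured step is available to size this change. No step beyond the scatter is expected, in either direction. This expectation rests on compound 2 with > 100000 nM as a limit. The expected step of a number no higher from compound 2 to compound 3 (the limit leaves the size open) is estimated to stay small. For compound 3 the estimated value is 100000 nM with an expected range of 60000 nM to 200000 nM in this estimate.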

Compound 3, half-maximal inhibitory concentration: 17400 nM
Compound 3: the middle estimate sits 5.7-fold (0.76 log units) above what was measured, and the stated range ends above it.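

In this assay the methoxy to hydroxy change gives an at least 5.7-fold lower number from compound 2 to compound 3 (0.75 log units; beyond the scatter) and brings a measured number into a set otherwise held at a limit. Methyl in place of methoxy on an aromatic carbon gives an at least 5.7-fold lower number from compound 1 to compound 3 (0.75 log units; beyond the scatter) and shows that the hydroxy alone does not leave the limit, just as the methyl alone does not in compound 2; among the compounds shown, only the pairing of hydroxy and methyl in compound 3 gives a number. Both steps are minimum sizes only, and their true sizes cannot be read because the starting compounds stand at a limit: the limit of > 100000 nM in this assay, at which 2 of the 3 values shown sit.

Going by these compounds, whether the free hydroxy itself matters remains open, since an ethoxy or an amine at that place would be needed to test it. Equally open, on these data alone, is how far the methyl can change, for instance to a chlorine, a longer chain or a carboxylic acid.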